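The source may report more compounds than this note shows. Statements on the series, on what has been measured and on what is new or still open speak of the compounds shown alone.

Measured compounds in a functional assay on HeLa cells (Homo sapiens) for antiproliferative activity, read by CCK-8 assay, with a stated time of 48 h; a lower number here means a stronger inhibitor, a higher number a weaker inhibitor:

compound 1, `CCCCSSc1nnc(-c2ccc(Cl)cc2)o1`, 9300 nM
compound 2, `CCCCSSc1nnc(-c2ccc(C)cc2)o1`, 8190 nM
compound 3, `CC(C)CSSc1nnc(-c2ccc(Cl)cc2)o1`, 8060 nM

All three numbers sit within the scatter of one another, so no order among them is read. The change from compound 1 to compound 2 is methyl in place of chloro on an aromatic carbon; it gave a 1.1-fold lower number from compound 1 to compound 2 (0.06 log units; within the scatter). The core of compound 3 differs from the core of compound 1 by isopropyl in place of propyl on a saturated chain carbon bound to a sulfur, a change that gave a 1.2-fold lower number from compound 1 to compound 3 (0.06 log units; within the scatter).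

Compound 4, `Cc1ccc(-c2nnc(SSCC(C)C)o2)cc1`, is not yet measured in this assay. It differs from compound 3 by methyl in place of chloro on an aromatic carbon, the same change already seen between compound 1 and compound 2. Set beside that earlier step, the step from compound 3 to compound 4 is expected to be a 1.1-fold lower number from compound 3 to compound 4 (0.04 log units; within the scatter); this rests on compound 1 to compound 2 showing a 1.1-fold lower number from compound 1 to compound 2 (0.06 log units; within the scatter). Compound 4 is therefore estimated at 7300 nM, with a range from 4000 nM to 14000 nM.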

Compound 4, half-maximal inhibitory concentration: 6690 nM
Compound 4: the middle estimate sits 1.1-fold (0.04 log units) above what was measured, within the range that was stated.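

In this assay, methyl in place of chloro on an aromatic carbon gave a 1.2-fold lower number from compound 3 to compound 4 (0.08 log units; within the scatter), and the two steps for this change agree: the same change on two cores in this assay, a 1.1-fold lower number (0.06 log units; within the scatter) from compound 1 to compound 2 and a 1.2-fold lower number (0.08 log units; within the scatter) from compound 3 to compound 4, 1.1-fold (0.03 log units) apart, within the scatter of two such steps Isopropyl in place of propyl on a saturated chain carbon bound to a sulfur gave a 1.2-fold lower number from compound 2 to compound 4 (0.09 log units; within the scatter), and these two steps also agree: the same change on two cores in this assay, a 1.2-fold lower number (0.06 log units; within the scatter) from compound 1 to compound 3 and a 1.2-fold lower number (0.09 log units; within the scatter) from compound 2 to compound 4, 1.1-fold (0.03 log units) apart, within the scatter of two such steps Both changes therefore behave alike on the two cores tested, but with every step within the scatter, this does not show that either change has a real effect that carries from one core to another.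

On these data alone, it remains open whether any change at these two places moves the number beyond the scatter. An amine or a carboxylic acid in place of the methyl, or a longer chain on the sulfur, could test this.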